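The source may report more compounds than this note shows. Statements on the series, on what has been measured and on what is new or still open speak of the compounds shown alone.

Compound 1, `COc1ccc(-c2nc3cc(NC(=O)[C@H](C)Oc4cccc(F)c4F)ccc3o2)cc1`, gives > 5000 nM in an assay on isolated protein for inhibition of GMP reductase 2 (Homo sapiens), read by spectrophotometry (a higher number here means a weaker inhibitor, a lower number a stronger inhibitor), a limit of the assay rather than a number. Compound 2, `C[C@H](Oc1cccc(Cl)c1Cl)C(=O)Nc1ccc2oc(C3=CC=NCC3=O)nc2c1`, gives > 5000 nM in this assay, again a limit.

Compound 2 therefore stands at the limit, where both shown values sit (the limit of > 5000 nM in this assay, at which 2 of the 2 values shown sit). Compound 3, `COc1ccc(-c2nc3cc(NC(=O)[C@H](C)Oc4cccc(Cl)c4Cl)ccc3o2)cc1`, differs from compound 2 by a group of 8 heavy atoms (7 carbon, 1 oxygen; one six-membered aromatic ring of carbon only) in place of a group of 7 heavy atoms (5 carbon, 1 nitrogen, 1 oxygen; one six-membered non-aromatic ring with 1 hetero atom), on an aromatic carbon. Compound 1 carries the same 4-methoxyphenyl group and also sits at the limit. Going by the values given here, no measured step between compounds differing in one place is available, so the size of this change in this assay cannot be read from the data; no step beyond the scatter is expected. Compound 3 is expected to give 10000 nM, between 3000 nM and 40000 nM, an expected step that the limit leaves unreadable from compound 2 to compound 3, most likely reported as another limit.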

Compound 3, inhibition constant: > 5000 nM
Compound 3: a limit, no number; the forecaster's own chance of this, stated with the estimate: 85%; the middle value does not contradict the limit.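

Compound 3 gives > 5000 nM in this assay, a limit and not a number. Going by these compounds alone, with compound 1 and compound 2 also at limits, no step among the three can be read. The compounds shown leave open how strongly any of them inhibits the enzyme, and what either exchange does to that inhibition.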